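This account rests on a few compounds, and the source may have more. Where it says the series, first, only, none or still open, it means among the compounds named here.

Working notes on the series, read in a functional assay on HepG2 cells (Homo sapiens) for antiproliferative activity, read by MTT assay, with a stated time of 48 h; on this read-out lower numbers stand for stronger inhibition of growth and higher numbers for weaker inhibition of growth. Compound 1 `CCCCCN(Cc1ccc(C(=O)NO)cc1)c1ncc(-c2ccc(C)cc2)s1` gives 7020 nM, compound 2 `Cc1ccc(OCCCN(Cc2ccc(C(=O)NO)cc2)c2ncc(-c3ccc(C)cc3)s2)cc1` gives 12200 nM and compound 3 `Cc1ccc(-c2cnc(N(CCCOc3ccccc3)Cc3ccc(C(=O)NO)cc3)s2)cc1` gives 23400 nM. Compound 3 stands at the high end of these numbers, with a 1.9-fold higher number from compound 2 to compound 3 (0.28 log units; within the scatter) and a 3.3-fold higher number from compound 1 to compound 3 (0.52 log units; beyond the scatter).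

The next compound is compound 4 `CCCN(Cc1ccc(C(=O)NO)cc1)c1ncc(-c2ccc(C)cc2)s1`, with this change: hydrogen in place of phenoxy on a saturated chain carbon, three bonds along the chain from a nitrogen on an aromatic ring. In words, this is hydrogen in place of phenoxy on a saturated chain carbon, three bonds along the chain from a nitrogen on an aromatic ring, so 3-phenoxypropyl becomes propyl.

The closest evidence is at that same carbon, where ethyl rather than hydrogen stands in place of phenoxy: a 3.3-fold higher number from compound 1 to compound 3 (0.52 log units; beyond the scatter). Read in reverse, this step points to a lower number on losing phenoxy. The matching step with 4-methylphenoxy, a 1.7-fold higher number from compound 1 to compound 2 (0.24 log units; within the scatter), runs the same way but is smaller. The step of a 1.9-fold higher number from compound 2 to compound 3 (0.28 log units; within the scatter) concerns only a methyl on an aromatic carbon and bears little on this change. For the measured compounds named here, no measured compound yet carries hydrogen at that carbon, so the reading is indirect.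

A modest step to a lower number is expected: a 2.8-fold lower number from compound 3 to compound 4 (0.44 log units; beyond the scatter). For compound 4 the estimated value is 8500 nM, with an expected range of 3500 nM to 20000 nM.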

Compound 4, concentration for 50% growth inhibition: 2550 nM
Beside the measured number, compound 4's estimate is 3.3-fold (0.52 log units) above it; measured number outside the range, below it.
By their numbers in this assay, from the lowest: compound 4; then compounds 1, 2 and 3 (each within the scatter of the next, the first and the last beyond it).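

In this assay, for the compounds shown here, the earlier compounds compared only groups that all extend the chain, and they left open whether any of these groups helps or hinders. Hydrogen at this saturated chain carbon now gives the lowest number of the set, and each substituted compound lies beyond the scatter from it: a 9.2-fold lower number from compound 3 to compound 4 (0.96 log units; beyond the scatter) on removing phenoxy, a 4.8-fold lower number from compound 2 to compound 4 (0.68 log units; beyond the scatter) on removing 4-methylphenoxy, and a 2.8-fold lower number from compound 1 to compound 4 (0.44 log units; beyond the scatter) on removing ethyl. Among these four compounds, then, ethyl, phenoxy and 4-methylphenoxy all go with weaker inhibition of growth than hydrogen, with no exception, although no measured property is available to explain this.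

The compounds shown leave open whether a small group at this carbon, such as a hydroxyl, an amine or a carboxylic acid, would keep the number of compound 4 or move it. They also leave open whether a chain shorter than propyl, such as ethyl or methyl on the same nitrogen, would lower the number further or whether propyl already marks the low end.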